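The source may hold more compounds than are shown below. What is called first, only, known or untested is meant among the compounds shown, and "the series" means these compounds.

In a functional assay on HCT-116 cells (Homo sapiens) for antiproliferative activity, with a stated time of 72 h (on this read-out lower numbers stand for stronger inhibition and higher numbers for weaker inhibition), compound 3 `Nc1ncnn2c([C@@H]3O[C@H](CO)[C@@H](O)[C@H]3O)cc(-c3ccc(Cl)cc3)c12` gives 59300 nM, the second highest of the three numbers. Compound 2 `Nc1ncnn2c([C@@H]3O[C@H](CO)[C@@H](O)[C@H]3O)cc(C#Cc3cccs3)c12` gives 65500 nM and stands nearest, with a 1.1-fold lower number from compound 2 to compound 3 (0.04 log units; within the scatter). Compound 1 `Nc1ncnn2c([C@@H]3O[C@H](CO)[C@@H](O)[C@H]3O)cc(C#CC3CC3)c12` gives 50 nM, far away: a 1200-fold higher number from compound 1 to compound 3 (3.07 log units; beyond the scatter), and likewise a 1300-fold higher number from compound 1 to compound 2 (3.12 log units; beyond the scatter). Compound 4 `COc1ccc(-c2cc([C@@H]3O[C@H](CO)[C@@H](O)[C@H]3O)n3ncnc(N)c23)cc1` differs from compound 3 by methoxy in place of chloro on an aromatic carbon. For the measured compounds named here, no measured step alters a group on the 4-chlorophenyl, so none bears on this change directly; the only step that leaves the aromatic substituent pattern otherwise intact, a 1.1-fold lower number from compound 2 to compound 3 (0.04 log units; within the scatter), was within the scatter, and nothing here suggests that swapping one small group for another on that ring moves this assay beyond the scatter in either direction. Compound 4 is therefore expected to give about 55000 nM, within 15000 nM to 200000 nM, the expected step being a 1.1-fold lower number from compound 3 to compound 4 (0.03 log units; within the scatter).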

Compound 4, half-maximal inhibitory concentration: 47100 nM
Estimate against measurement, compound 4: 1.2-fold (0.07 log units) above, within the range that was stated.
By their numbers in this assay, from the lowest: compound 1; then compounds 4, 3 and 2 (each within the scatter of the next).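

In this assay, the step on the ring itself (a 1.3-fold lower number from compound 3 to compound 4 (0.10 log units; within the scatter)) stays within the scatter, so methoxy and chloro on this six-membered aromatic ring cannot be told apart here. The 4-methoxyphenyl group also stands level with 2-(thiophen-2-yl)ethynyl (a 1.4-fold lower number from compound 2 to compound 4 (0.14 log units; within the scatter)), while the large gap to 2-cyclopropylethynyl persists (a 940-fold higher number from compound 1 to compound 4 (2.97 log units; beyond the scatter)), so this change does not close that gap. Nothing measured here explains these steps. As far as these compounds go, whether an amine or a carboxylic acid on this ring would move the number beyond the scatter stays open, as does the effect of a longer chain on the triple bond in place of cyclopropyl.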